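The source may report more compounds than this note shows. Statements on the series, on what has been measured and on what is new or still open speak of the compounds shown alone.

Measured compounds:
compound 1 `Cc1nc(NC(=O)c2ccccc2)sc1C(=O)/C=C/c1ccccc1` — 73.5%
compound 2 `Cc1nc(NC(=O)c2ccccc2)sc1C(=O)/C=C/c1ccc(Cl)cc1` — 63.7%
compound 3 `Cc1nc(NC(=O)c2ccccc2)sc1C(=O)/C=C/c1cccc([N+](=O)[O-])c1` — 98%

In an assay for inhibition of Polyunsaturated fatty acid 5-lipoxygenase (Homo sapiens), read by spectrophotometry, tested at 10 uM, in the presence of a further agent that is not named here (on this read-out higher numbers stand for more inhibition at the one concentration tested (going by the name of the read-out) and lower numbers for less inhibition), compound 3 stands highest of the three; its steps to compound 1 and compound 2 both lie beyond the scatter: a number 24.5 percentage points higher from compound 1 to compound 3 (beyond the scatter) and a number 34.3 percentage points higher from compound 2 to compound 3 (beyond the scatter). Compound 4 `Cc1nc(NC(=O)c2ccccc2)sc1C(=O)/C=C/c1ccc(N(C)C)cc1` differs from compound 3 in one place: 4-(dimethylamino)phenyl in place of 3-nitrophenyl on a double-bonded chain carbon bound to a double-bonded chain carbon. Among the measured compounds shown here, the steps that bear on this are the two ring-substituent changes, a number 24.5 percentage points higher from compound 1 to compound 3 (beyond the scatter) and a number 34.3 percentage points higher from compound 2 to compound 3 (beyond the scatter), while a number 9.8 percentage points lower from compound 1 to compound 2 (within the scatter). For the measured compounds named here, compound 4 carries no nitro group, and the only nitro-bearing compound, compound 3, stands above both compounds without one; no measured compound carries a dimethylamino group, so its effect is unknown. A downward step beyond the scatter is therefore expected, a number 33 percentage points lower from compound 3 to compound 4 (beyond the scatter), towards the range of compound 1 and compound 2. Compound 4 is estimated at 65%, between 40% and 88%.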

Compound 4, a percentage reported as inhibition, at one concentration (the size of the read-out at that concentration, not a potency): 88.2%
The estimate for compound 4 lay 23.2 percentage points below the measured number, and the stated range ends below it.
By their numbers in this assay, from the lowest: compounds 2 and 1 (each within the scatter of the next); then compounds 4 and 3 (each within the scatter of the next).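

In this assay a high number at this chain position does not depend on a nitro group: the exchange of 3-nitrophenyl for 4-(dimethylamino)phenyl reads as a number 9.8 percentage points lower from compound 3 to compound 4 (within the scatter). Dimethylamino also stands clear of the other two ring states, with a number 14.7 percentage points higher from compound 1 to compound 4 (beyond the scatter) and a number 24.5 percentage points higher from compound 2 to compound 4 (beyond the scatter). No measurement here bears on the reason for this result.

Going by these compounds, the two high compounds carry different groups at different ring positions, so the separate contributions of group and ring position stay open. On these data alone, how a carboxylic acid or a longer amine chain on this ring would read also stays open.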